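Swapping a Distal Phenyl for Chloro on a Bromoacrylamide Conjugate

This account rests on a few compounds, and the source may have more. Where it says the series, first, only, none or still open, it means among the compounds named here.

Two compounds have numbers in a functional assay on L1210 cells (Mus musculus) for antiproliferative activity; a higher number here means a weaker inhibitor, a lower number a stronger inhibitor. Compound 1 `C=C(Br)C(=O)Nc1ccc2oc(C(=O)NCCNC(=O)c3cc(OCC4(c5ccc(-c6ccccc6)cc5)CC(=C)C(=O)O4)nn3C)cc2c1` gives 270 nM in this assay, the lower of the two numbers. Compound 2 `C=C(Br)C(=O)Nc1ccc2c(c1)cc(C(=O)O)n2C` gives 2070 nM, and the gap between the two lies beyond the scatter of repeated measurements. The two differ in several places, so the gap cannot be tied to any single change.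

Compound 3 `C=C(Br)C(=O)Nc1ccc2oc(C(=O)NCCNC(=O)c3cc(OCC4(c5ccc(Cl)cc5)CC(=C)C(=O)O4)nn3C)cc2c1` differs from compound 1 in one place: chloro in place of phenyl on an aromatic carbon. Among the measured compounds shown here, no pair of measured compounds shows what such a swap does, so any expectation rests on compound 1 alone and carries a wide range. A moderate weakening is expected for compound 3, since a large part of the outer group is removed, and the step of a 2.0-fold higher number from compound 1 to compound 3 (0.31 log units; beyond the scatter) is estimated to fall just beyond the scatter. Compound 3 is expected to give about 550 nM, within roughly 150 nM to 2000 nM.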

Compound 3, half-maximal inhibitory concentration: 550 nM
The estimate for compound 3 equals the measured number at the digits printed; the measured number falls inside the stated range.
By their numbers in this assay, from the lowest: compound 1; then compound 3; then compound 2.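

Among the compounds shown here, the swap gives the first one-place comparison in this set: in this assay, going from 4-phenylphenyl to 4-chlorophenyl gives a 2.0-fold higher number from compound 1 to compound 3 (0.31 log units; beyond the scatter), a modest step. At this position, on an aromatic carbon para to a large group, the outer six-membered ring is therefore not required for activity: six carbon atoms give way to one chlorine, and only a modest loss follows. Nothing measured here explains the size of this step.

A single swap cannot show whether the trend depends on the size of the group or on the particular atoms it contains. A hydrogen, a methoxy group or a longer chain at the same place would help separate these possibilities, and a second pair on a different core would show whether the step carries over.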